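Removing a carbamoylmethyl group from a diphenylpropyl amide

The compounds below may be only part of what the source reports. "The series", "measured", "known", "first", "only" and "open" are said of these compounds alone.

Going by the values given here, compound 1 `NC(=O)CN(CCC(c1ccccc1)c1ccccc1)C(=O)CNCCC(c1ccccc1)c1ccccc1` is the one compound in this set for which a number is known: in an ADME assay on MDA-MB-231 cells (Homo sapiens) for cytotoxicity, with a stated time of 72 h (a lower number here means a stronger inhibitor of growth, a higher number a weaker inhibitor of growth), compound 1 gives 3080 nM. Two related compounds offer no comparison: in this assay compound 2 `O=C1CN(CC2CCCO2)C(=O)CN1CCC(c1ccccc1)c1ccccc1` gives "not determined" (no result reported), and compound 3 `NC(=O)CN(CC1CCCO1)C(=O)CNCCC(c1ccccc1)c1ccccc1` gives "not determined" (no result reported). Compound 4 `O=C(CNCCC(c1ccccc1)c1ccccc1)NCCC(c1ccccc1)c1ccccc1` shares the core of compound 1 and differs from it in one place: hydrogen in place of carbamoylmethyl on an amide-type nitrogen. Among the compounds with values here, no pair of measured compounds with a single change is available, so the size of this step can only be guessed from the change itself. The author expects the step from compound 1 to compound 4 to be small, not beyond the usual scatter of this assay, with no clear direction, so that a 1.1-fold higher number from compound 1 to compound 4 (0.06 log units; within the scatter) is the expected change. Compound 4 is therefore estimated at 3500 nM, with a range from 1200 nM to 10000 nM in this assay, pending the measurement.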

Compound 4, concentration for 50% growth inhibition: 3460 nM
Estimate against measurement, compound 4: 1.0-fold (0.00 log units) above, within the range that was stated.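

In this assay, replacing the carbamoylmethyl group on the amide-type nitrogen with hydrogen gives a 1.1-fold higher number from compound 1 to compound 4 (0.05 log units; within the scatter) and so stays within the usual scatter. Going by these compounds alone, this is the first measured reading at this position: the group, with its double bond outside aromatic rings and its hydrogen-bond donor and acceptor, can be exchanged for hydrogen without a separable difference in growth inhibition in this pair. No available measurement explains this result.

A single pair cannot show whether other groups on this nitrogen, such as an amine, a carboxylic acid or a longer chain, would also stay within the scatter. On these data alone, compound 2 and compound 3 have no reported result, so any steps involving them cannot be read, and the effect of a tetrahydrofuran-2-ylmethyl group remains open.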